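Anilinoquinazoline series: cytotoxicity on MCF7, the aminophenyl analogue

This account rests on a few compounds, and the source may have more. Where it says the series, first, only, none or still open, it means among the compounds named here.

Measured compounds:
Compound 1, `Fc1cccc(-c2nc(Nc3cccc(Br)c3)c3cc(F)ccc3n2)c1`. In a functional assay on MCF7 cells (Homo sapiens) for cytotoxicity, read by MTT assay, with a stated time of 48 h (a higher number here means a weaker inhibitor, a lower number a stronger inhibitor), compound 1 gives the limit > 50000 nM.
Compound 2, `Fc1cccc(-c2nc(Nc3ccccc3Br)c3cc(F)ccc3n2)c1`. In this assay compound 2 gives the limit > 50000 nM.
Compound 3, `Oc1ccc(Nc2nc(-c3cccc(F)c3)nc3ccc(F)cc23)cc1`. In this assay compound 3 gives the limit > 50000 nM.

Compound 3 stands on a limit only, and all three values shown in this assay are that same limit (the limit of > 50000 nM in this assay, at which 3 of the 3 values shown sit). The steps among the measured compounds are accordingly not readable: a step that the two limits leave unreadable from compound 1 to compound 2, a step that the two limits leave unreadable from compound 1 to compound 3 and a step that the two limits leave unreadable from compound 2 to compound 3.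

Compound 4, `Nc1ccccc1Nc1nc(-c2cccc(F)c2)nc2ccc(F)cc12`, is not yet measured. It differs from compound 3 by 2-aminophenyl in place of 4-hydroxyphenyl on a nitrogen on an aromatic ring. Among the measured compounds shown here, the three measured steps, all of which exchange one substituted phenyl for another on the same nitrogen, give no readable size in either direction, so nothing beyond the scatter can be predicted, and the bearing evidence is that every compound so far sits at the limit (the limit of > 50000 nM in this assay, at which 3 of the 3 values shown sit).

The step from compound 3 to compound 4 is therefore expected to be a number no higher from compound 3 to compound 4 (the limit leaves the size open), which here means that compound 4 is most likely to return a limit again. The estimate for compound 4 in this assay is 50000 nM, within 15000 nM to 150000 nM.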

Compound 4, half-maximal inhibitory concentration: > 50000 nM
Compound 4 gave a limit, no number; the forecaster's own chance of this, stated with the estimate: 85%; the middle value sits exactly at the limit.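

In this assay compound 4 gives the limit > 50000 nM and no number. Among the compounds shown here, no step between compound 4 and compound 1, compound 2 or compound 3 can be read, and every value shown is the same limit: the limit of > 50000 nM in this assay, at which 4 of the 4 values shown sit.

The compounds shown leave open what size any of these exchanges on the nitrogen has in this assay.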